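Replacing an Amino Link on a Carbonyl Carbon

This account rests on a few compounds, and the source may have more. Where it says the series, first, only, none or still open, it means among the compounds named here.

Measured so far:
- compound 1 `COc1cc(Cl)cc(-c2nn(-c3cccc(NC(=O)Nc4ccc(Cl)c(C(F)(F)F)c4)c3)cc2-c2ccncc2)c1` gives 45%
- compound 2 `COc1cc(Cl)cc(-c2nn(-c3cccc(NC(=O)Nc4cccc(C(F)(F)F)c4)c3)cc2-c2ccncc2)c1` gives 65%

Both numbers come from a functional assay on ACHN cells (Homo sapiens) for inhibition, read by sulforhodamine B assay, with a stated time of 48 h, tested at 1 uM; a lower number here means a stronger effect, a higher number a weaker effect of the compound at the concentration tested. For the measured compounds named here, of the two, compound 2 stands highest, so its effect is the weaker; the only measured step, a number 20 percentage points higher from compound 1 to compound 2 (beyond the scatter), separates it from compound 1.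

Compound 3 `COc1cc(Cl)cc(-c2nn(-c3cccc(NC(=O)c4cccc(C(F)(F)F)c4)c3)cc2-c2ccncc2)c1` is not yet measured. Its difference from compound 2 is 3-(trifluoromethyl)phenyl in place of (3-(trifluoromethyl)phenyl)amino on a carbonyl carbon. Going by the values given here, no measured step touches this part of the shared core: the one step known, a number 20 percentage points higher from compound 1 to compound 2 (beyond the scatter), concerns a chloro on a distant aromatic ring and says nothing about what happens on the carbonyl carbon. With nothing to guide a direction, the expected step of no change at the digits printed from compound 2 to compound 3 (within the scatter) is none beyond the scatter. Compound 3 is therefore estimated at 65%, within a range of 45% to 85%.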

Compound 3, a percentage reported as activity, at one concentration (the size of the read-out at that concentration, not a potency): 54%
For compound 3 the middle estimate is 11 percentage points above the measured one; low and high end bracket the measured number.
By their numbers in this assay, from the lowest: compounds 1 and 3 (each within the scatter of the next); then compound 2.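

In this assay, setting the 3-(trifluoromethyl)phenyl directly on the carbonyl carbon in place of its amino-linked form gives a number 11 percentage points lower from compound 2 to compound 3 (beyond the scatter). This shows that the carbonyl position responds to the change and that the effect at the tested concentration survives without the amino link and its hydrogen-bond donor. The step that also removes the chloro, a number 9 percentage points higher from compound 1 to compound 3 (within the scatter), leaves those two compounds unseparated, and no measured evidence accounts for either step.

As far as these compounds go, it remains open whether a chloro added to the aromatic ring of compound 3 would lower its number, as the chloro of compound 1 does relative to compound 2. Other groups on the carbonyl carbon, such as a benzyl or a phenoxy group, also remain untested in the compounds shown here.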